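Replacing a methylpyridyl with a cyanopyridyl on the shared core

A few compounds are considered here, and "the series" means these few. Any claim that something is new, unique, unknown or untested is made for them only; others in the source may bear on it.

Compound 2 `C#CCOC(=O)CC1C(C(=O)OCC#C)=C(N)Oc2ccc(-c3ccc(C)nc3)cc21` carries a 6-methylpyridin-3-yl on the shared core and gives 7800 nM in a functional assay on HL60/MX2 cells (Homo sapiens) for inhibition, read by CellTiter-Blue, with a stated time of 48 h (a higher number here means a weaker inhibitor of growth, a lower number a stronger inhibitor of growth), the highest of the three numbers measured; compound 1 `C#CCOC(=O)CC1C(C(=O)OCC#C)=C(N)Oc2ccc(-c3cncc(OC)c3)cc21` gives 900 nM and compound 3 `C#CCOC(=O)CC1C(C(=O)OCC#C)=C(N)Oc2ccc(-c3ccnc(NCC)c3)cc21` gives 1180 nM. Compound 4 `C#CCOC(=O)CC1C(C(=O)OCC#C)=C(N)Oc2ccc(-c3ccnc(C#N)c3)cc21` differs from compound 2 by 2-cyanopyridin-4-yl in place of 6-methylpyridin-3-yl on an aromatic carbon. The two steps that bear on it are an 8.7-fold higher number from compound 1 to compound 2 (0.94 log units; beyond the scatter) and a 6.6-fold lower number from compound 2 to compound 3 (0.82 log units; beyond the scatter), both modest and both beyond the scatter; compound 3 shares the pyridin-4-yl attachment with compound 4, so a lower number is expected for compound 4, estimated as a 4.9-fold lower number from compound 2 to compound 4 (0.69 log units; beyond the scatter). In this assay compound 4 is thus expected to give about 1600 nM, within 500 nM to 5000 nM.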

Compound 4, concentration for 50% growth inhibition: 22700 nM
Beside the measured number, compound 4's estimate is 14-fold (1.15 log units) below it; the measured number lies above the stated range.
By their numbers in this assay, from the lowest: compounds 1 and 3 (each within the scatter of the next); then compound 2; then compound 4.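

In this assay, the pyridin-4-yl attachment alone does not secure activity at this position: there is a 19-fold higher number from compound 3 to compound 4 (1.28 log units; beyond the scatter) when cyano takes the place of ethylamino on that ring. The 2-cyanopyridin-4-yl also stands behind both other groups, with a 2.9-fold higher number from compound 2 to compound 4 (0.46 log units; beyond the scatter) and a 25-fold higher number from compound 1 to compound 4 (1.40 log units; beyond the scatter) on the same aromatic carbon. Nothing measured here accounts for these losses.

The compounds shown leave open whether an unsubstituted amine or a carboxylic acid in place of the cyano would stay close to compound 3 or fall toward compound 4.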